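Chloro to methoxy swap on the pendant phenyl ring

This account rests on a few compounds, and the source may have more. Where it says the series, first, only, none or still open, it means among the compounds named here.

Measured so far in a functional assay on L1210 cells (Mus musculus) for inhibition, read by cell counting, with a stated time of 2 days; on this read-out higher numbers stand for weaker inhibition and lower numbers for stronger inhibition:
compound 1 `Nc1cccc(-c2cn3nc(Cc4ccc(Cl)cc4)sc3n2)c1` gives 16000 nM
compound 2 `COc1ccc(Cc2nn3cc(-c4cccc(N)c4)nc3s2)cc1` gives 227000 nM
compound 3 `C=C(Br)C(=O)Nc1cccc(-c2cn3c(-c4ccc(Cl)cc4)csc3n2)c1` gives 1900 nM

Compound 1 and compound 2 differ only by methoxy in place of chloro on an aromatic carbon; this gave a 14-fold higher number from compound 1 to compound 2 (1.15 log units; beyond the scatter). Compound 3 has the lowest number of the three in this assay; how its core differs from that of compound 1 is not broken down here.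

Compound 4 `C=C(Br)C(=O)Nc1cccc(-c2cn3c(-c4ccc(OC)cc4)csc3n2)c1` is unmeasured and differs from compound 3 by methoxy in place of chloro on an aromatic carbon, the same change as that from compound 1 to compound 2, made at the same kind of place. The expected step in this assay is an 11-fold higher number from compound 3 to compound 4 (1.02 log units; beyond the scatter), resting on the earlier step of a 14-fold higher number from compound 1 to compound 2 (1.15 log units; beyond the scatter), with some doubt as to whether the different core of compound 3 will carry it unchanged. Compound 4 is therefore estimated at 20000 nM, between 5000 nM and 80000 nM.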

Compound 4, half-maximal inhibitory concentration: 200 nM
The estimate for compound 4 lay 100-fold (2.00 log units) above the measured number; measured number outside the range, below it.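

In this assay, 4-chlorophenyl to 4-methoxyphenyl on the core of compound 3 gives a 9.5-fold lower number from compound 3 to compound 4 (0.98 log units; beyond the scatter), so methoxy in place of chloro does not keep its direction from one core to the other. The two steps differ by more than the scatter: the same change on two cores in this assay, a 14-fold higher number (1.15 log units; beyond the scatter) from compound 1 to compound 2 and a 9.5-fold lower number (0.98 log units; beyond the scatter) from compound 3 to compound 4, 130-fold (2.13 log units) apart, beyond the scatter of two such steps This shows that a step read on the core of compound 1 cannot be carried over to the core of compound 3, but it does not show which of the several differences between the two cores is responsible, and two pairs set no rule for any further core.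

Still open, on these data alone, is whether a fluoro, hydroxyl or carboxylic acid group in the same place would follow the step on the core of compound 1 or that on the core of compound 3. Also open, as far as these compounds go, is how far the opposite directions extend to other groups on these two cores.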